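The source may hold more compounds than are shown below. What is called first, only, known or untested is meant among the compounds shown, and "the series" means these compounds.

For the measured compounds named here, compound 2 `CCn1c(C(=O)OC(C)CCO)ccc1C(CC)(CC)c1ccc(OCC(=O)C(C)(C)C)c(C)c1` holds the lowest of the two numbers so far in an assay on HL-60 cells for agonist activity at vitamin D3 receptor (Homo sapiens), read by microscopy, with a stated time of 96 h (a higher number here means that more compound is needed for the effect, a lower number that less compound is needed), where compound 2 gives 380 nM. Going by the values given here, its nearest neighbour is compound 1 `C=CCN(C)C(=O)c1ccc(C(CC)(CC)c2ccc(OCC(=O)C(C)(C)C)c(C)c2)n1CC`, which in this assay gives 21600 nM; the single change between them, a 57-fold lower number from compound 1 to compound 2 (1.75 log units; beyond the scatter), is the only measured step available. Compound 3 `CCn1c(C(=O)N(C)CC(=O)O)ccc1C(CC)(CC)c1ccc(OCC(=O)C(C)(C)C)c(C)c1` is not yet measured. It differs from compound 2 in one place: a group of 6 heavy atoms (3 carbon, 1 nitrogen, 2 oxygen; no ring) in place of a group of 6 heavy atoms (4 carbon, 2 oxygen; no ring), on a carbonyl carbon. Among the compounds with values here, the one step that bears on this change, a 57-fold lower number from compound 1 to compound 2 (1.75 log units; beyond the scatter), went from a nitrogen-bearing group to an oxygen-bearing group on the same carbonyl carbon and brought a large fall in the number. Compound 3 puts a nitrogen-bearing group back on that carbonyl carbon, so a rise beyond the scatter, though not necessarily of the full earlier size, is expected: a 7.9-fold higher number from compound 2 to compound 3 (0.90 log units; beyond the scatter). Compound 3 is therefore estimated to give about 3000 nM in this assay, within a range from 600 nM to 20000 nM.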

Compound 3, half-maximal effective concentration: 1390 nM
Estimate against measurement, compound 3: 2.2-fold (0.33 log units) above, and the stated range covers the measured number.
By their numbers in this assay, from the lowest: compound 2; then compound 3; then compound 1.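

The nitrogen of the amide does not by itself set the number at this carbonyl carbon: with (carboxymethyl)(methyl)amino in place of the earlier oxygen-bearing group, this assay shows only a modest rise (a 3.7-fold higher number from compound 2 to compound 3 (0.56 log units; beyond the scatter)). What lies further along the amide chain counts for much more, since carboxy in place of vinyl on the saturated chain carbon bound to the amide-type nitrogen gives a large fall (a 16-fold lower number from compound 1 to compound 3 (1.19 log units; beyond the scatter)). Nothing available explains either step.

The compounds shown leave open whether a hydroxyl or an amine in place of the carboxy group would hold the number near that of compound 3. They also leave open whether a longer chain between the amide-type nitrogen and the carboxy group would move it.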